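The compounds below may be only part of what the source reports. "The series", "measured", "known", "first", "only" and "open" are said of these compounds alone.

Measured compounds:
- compound 1 `CC(C)n1cnc2c(Nc3ccccc3)nc(NCOCc3ccc(C(=O)Nc4ccccc4N)cc3)nc21`: 15%
- compound 2 `Nc1ccccc1NC(=O)/C=C/c1ccc(COCNc2nc(Nc3cccc(Cl)c3)c3ncn(C4CCCC4)c3n2)cc1`: 37.1%
- compound 3 `CC(C)n1cnc2c(Nc3cccc(Cl)c3)nc(NCOCc3ccc(/C=C/C(=O)Nc4ccccc4N)cc3)nc21`: 53%

All three were run in a functional assay on NCI-H460 cells (Homo sapiens) for antiproliferative activity, read by CCK-8 assay, with a stated time of 72 h, tested at 2 uM; a lower number here means a weaker effect, a higher number a stronger effect of the compound at the concentration tested. Within this set compound 1 has the lowest number; the nearest is compound 2, and the gap to compound 3 is larger still, both gaps beyond the scatter.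

Compound 3 and compound 2 differ in one place: cyclopentyl in place of isopropyl on an aromatic nitrogen. That change cost a number 15.9 percentage points lower from compound 3 to compound 2 (beyond the scatter), a modest loss lying beyond the scatter. Compound 1 and compound 3 differ in more than one place, and the difference between the two cores is not broken down here; only their two values are available for comparison.

Compound 4 `Nc1ccccc1NC(=O)c1ccc(COCNc2nc(Nc3ccccc3)c3ncn(C4CCCC4)c3n2)cc1` is not yet measured in this assay. It arises from compound 1 by cyclopentyl in place of isopropyl on an aromatic nitrogen. The place of the change is described in the same words for both pairs, so this is the same change as that from compound 3 to compound 2, now made on the core of compound 1.

Expectation for compound 4: the step is estimated at a number 9 percentage points lower from compound 1 to compound 4 (within the scatter), resting on the earlier loss of a number 15.9 percentage points lower from compound 3 to compound 2 (beyond the scatter) and on the fact that compound 1 already starts from 15%, so that little room remains downward. Compound 4 is therefore expected to give about 6% in this assay, with a likely range from 0% to 22%.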

Compound 4, a percentage reported as inhibition, at one concentration (the size of the read-out at that concentration, not a potency): 41.2%
For compound 4 the middle estimate is 35.2 percentage points below the measured one; measured number outside the range, above it.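

On the core of compound 1, cyclopentyl in place of isopropyl on an aromatic nitrogen gives, in this assay, a number 26.2 percentage points higher from compound 1 to compound 4 (beyond the scatter). Set beside the earlier step, the same change does not carry from one core to the other, either in direction or in size: the same change on two cores in this assay, a number 15.9 percentage points lower (beyond the scatter) from compound 3 to compound 2 and a number 26.2 percentage points higher (beyond the scatter) from compound 1 to compound 4, 42.1 percentage points apart, beyond the scatter of two such steps

For the compounds shown here, for these two pairs, the outcome of the change therefore depends on the core it is made on, so a step measured on one core is a poor guide to the other; with only two pairs, however, this shows neither which of the several differences between the cores matters nor how the change would behave on any further core, and as each read-out is taken at a single concentration, it shows nothing about potency.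

Which of the places where the two cores differ decides the direction of the step remains open, and a pair differing in only one of those places would be needed to settle it. Also open, as far as these compounds go, is whether cyclohexyl or a longer chain such as n-butyl on the same aromatic nitrogen would follow the step seen on the core of compound 1 or the step seen on the core of compound 3.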